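Cytotoxicity in a Sulfonyl Piperidine Series: Aryl Swap

A few compounds are considered here, and "the series" means these few. Any claim that something is new, unique, unknown or untested is made for them only; others in the source may bear on it.

This account follows one sulfonyl piperidine series in an ADME assay on HCT-116 cells (Homo sapiens) for cytotoxicity, read by CellTiter-Glo, with a stated time of 72 h; on this read-out lower numbers stand for stronger inhibition and higher numbers for weaker inhibition. Compound 1 is `CC1CCN(C2CCN(S(=O)(=O)c3cccc(N)c3)CC2)CC1`, and compound 2 is `CC1CCN(C2CCN(S(=O)(=O)c3cccnc3F)CC2)CC1`. In this assay compound 1 gives only a limit, > 5000 nM. In this assay compound 2 also gives only a limit, > 10000 nM. The step from compound 1 to compound 2 is therefore a step that the two limits leave unreadable from compound 1 to compound 2, and compound 2 stands at the limit described by the limit of > 10000 nM in this assay, at which 1 of the 2 values shown sits, with compound 1 at the limit described by the limit of > 5000 nM in this assay, at which 1 of the 2 values shown sits. Compound 3, not yet measured, is `CC1CCN(C2CCN(S(=O)(=O)c3cccc(Cl)c3)CC2)CC1`. It differs from compound 2 as follows: 3-chlorophenyl in place of 2-fluoropyridin-3-yl on a sulfonyl sulfur. No measured step bears directly on this change, since the single step shown is unreadable and neither compound 2 nor compound 1 reaches a number. The expectation therefore rests only on the fact that both measured compounds sit at limits, and the step from compound 2 to compound 3 is expected to be a step that the limit leaves unreadable from compound 2 to compound 3, with no readable direction. Compound 3 is estimated at 15000 nM, in a range from 5000 nM to 50000 nM, most likely reported again as a limit.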

Compound 3, half-maximal inhibitory concentration: > 5000 nM
Compound 3 ended at the assay's limit; the forecaster's own chance of this, stated with the estimate: 80%; the middle value is on the limit's open side.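

In this assay compound 3 gives only a limit, > 5000 nM. With limits alone, neither the step from compound 2 to compound 3 nor the step from compound 1 to compound 3 can be read. The compounds shown leave open whether 3-aminophenyl, 2-fluoropyridin-3-yl and 3-chlorophenyl on the sulfonyl sulfur differ at all in this read-out.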